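A Trifluoromethylphenyl Group Replaces a Sulfur-Bearing Ring

A few compounds are considered here, and "the series" means these few. Any claim that something is new, unique, unknown or untested is made for them only; others in the source may bear on it.

Of the compounds shown here, three sharing one core have been measured so far in a functional assay on Shh Light II cells (Mus musculus) for inhibition, read by a luciferase reporter (on this read-out higher numbers stand for weaker inhibition and lower numbers for stronger inhibition), with quite different groups on the carbonyl carbon. Compound 1 `O=C(CC1CCCCCC1)N1CCC(c2nc(-c3ccc4ccccc4n3)no2)CC1` gives 840 nM and compound 2 `O=C(NC1CCS(=O)(=O)CC1)N1CCC(c2nc(-c3ccc4ccccc4n3)no2)CC1` gives 360 nM under these conditions. Compound 3 `O=C(NC1CC[S+]([O-])CC1)N1CCC(c2nc(-c3ccc4ccccc4n3)no2)CC1` gives 850 nM and so stands level with compound 1 (a 1.0-fold higher number from compound 1 to compound 3 (0.01 log units; within the scatter)). Compound 3 is the weaker partner in its comparison with compound 2 (a 2.4-fold higher number from compound 2 to compound 3 (0.37 log units; beyond the scatter)).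

Compound 4 `O=C(Nc1ccccc1C(F)(F)F)N1CCC(c2nc(-c3ccc4ccccc4n3)no2)CC1` keeps the shared core and the carbonyl but carries 2-(trifluoromethyl)phenyl on the amide-type nitrogen (a group of 10 heavy atoms (7 carbon, 3 fluorine; one six-membered aromatic ring of carbon only) in place of a group of 7 heavy atoms (5 carbon, 1 oxygen, 1 sulfur; one six-membered non-aromatic ring with 1 hetero atom), on an amide-type nitrogen). The closest evidence is the change on that same nitrogen (a 2.4-fold higher number from compound 2 to compound 3 (0.37 log units; beyond the scatter)) together with the swap that produced compound 2 (a 2.3-fold lower number from compound 1 to compound 2 (0.37 log units; beyond the scatter)). Both of these steps were modest. Among the measured compounds shown here, no measured compound has an aromatic ring in that place, so the data offer no direct test of this group. Modest steps remain the only guide, and no change beyond the scatter is expected in this assay with an estimated move of a 1.7-fold lower number from compound 3 to compound 4 (0.23 log units; within the scatter) for now. Compound 4 is estimated at 500 nM within an expected range from 150 nM to 1600 nM for now.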

Compound 4, half-maximal inhibitory concentration: 700 nM
For compound 4 the middle estimate is 1.4-fold (0.15 log units) below the measured one; the measured number falls inside the stated range.
By their numbers in this assay, from the lowest: compounds 2, 4, 1 and 3 (each within the scatter of the next, the first and the last beyond it).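

Among the compounds shown here, the 2-(trifluoromethyl)phenyl group is the first aromatic ring seen on this amide-type nitrogen, and in this assay it cannot be told apart from the sulfur-bearing ring it replaces (a 1.2-fold lower number from compound 3 to compound 4 (0.08 log units; within the scatter)) or from the cycloheptylmethyl group on the carbonyl carbon (a 1.2-fold lower number from compound 1 to compound 4 (0.08 log units; within the scatter)). For the compounds shown here, the comparison with the best number so far also stays inside the usual scatter (a 1.9-fold higher number from compound 2 to compound 4 (0.29 log units; within the scatter)), so this position accepts an aromatic carbon ring carrying fluorine as readily as a saturated sulfur-bearing ring, and the only step here that goes against this picture of a flat response is the one beyond the scatter from compound 2 to compound 3 (a 2.4-fold higher number from compound 2 to compound 3 (0.37 log units; beyond the scatter)). No measurement available here explains why such different groups give such similar numbers.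

Going by these compounds, it remains open whether the trifluoromethyl group contributes anything, since a plain phenyl ring, or a phenyl ring bearing chlorine or a methoxy group instead, would be needed to separate its share from that of the ring. An amine or a carboxylic acid on that ring would show whether this tolerance extends to quite different groups.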